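Aryl sulfamate series: hydroxyethyl replacing furanyl on the aniline arm

The compounds below may be only part of what the source reports. "The series", "measured", "known", "first", "only" and "open" are said of these compounds alone.

Compound 2 `NS(=O)(=O)Oc1ccc2c(c1)CN(C(=O)c1cccc(N(Cc3ccccc3)Cc3ccco3)c1)CC2` is assessed in an assay on HEK293 cells for inhibition of Steryl-sulfatase (Homo sapiens), tested at 0.1 uM (a lower number here means a weaker effect, a higher number a stronger effect of the compound at the concentration tested), where compound 2 gives 27.5%. For the measured compounds named here, this is the highest of the three numbers so far, though compound 1 `CN(C)CCCN(Cc1ccccc1)c1cccc(C(=O)N2CCc3ccc(OS(N)(=O)=O)cc3C2)c1` with 23.8% lies within the scatter of it. Going by the values given here, compound 3 `CCN(Cc1ccccc1)Cc1ccc(CN2CCc3ccc(OS(N)(=O)=O)cc3C2)cc1` sits well apart at 1%; no single-point step connects compound 3 to compound 2, so its value is noted only as the low end of the set.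

The change to compound 4 `NS(=O)(=O)Oc1ccc2c(c1)CN(C(=O)c1cccc(N(CCCO)Cc3ccccc3)c1)CC2` is 2-hydroxyethyl in place of furan-2-yl on a saturated chain carbon bound to a nitrogen on an aromatic ring. Among the compounds with values here, the one measured step at this same place, a number 3.7 percentage points higher from compound 1 to compound 2 (within the scatter), was within the scatter, so swapping one group at this position for another has so far left the read-out essentially unmoved. On that basis the expected step in this assay is a number 3.5 percentage points lower from compound 2 to compound 4 (within the scatter), that is, none beyond the scatter, with a slight lean downward only as an allowance for the lost ring. Compound 4 is therefore estimated at 24%, in the range 12% to 36%.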

Compound 4, a percentage reported as inhibition, at one concentration (the size of the read-out at that concentration, not a potency): 25.8%
For compound 4 the middle estimate is 1.8 percentage points below the measured one, and the stated range covers the measured number.
By their numbers in this assay, from the lowest: compound 3; then compounds 1, 4 and 2 (each within the scatter of the next).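

Furan-2-yl gives way to the open-chain 2-hydroxyethyl at this place, on a saturated chain carbon bound to a nitrogen on an aromatic ring, with a number 1.7 percentage points lower from compound 2 to compound 4 (within the scatter) in this assay, so among these compounds the five-membered aromatic ring is not required to hold the read-out. The comparison at the chain end, hydroxy in place of dimethylamino, gives a number 2 percentage points higher from compound 1 to compound 4 (within the scatter), so the arms of compound 1, compound 2 and compound 4 cannot be told apart in this read-out. Nothing available explains why these different groups read alike.

A carboxylic acid at the chain end, a longer chain, or a phenyl ring in place of the furan-2-yl could still separate from these three. From the compounds shown here alone, all values come from a single test concentration, so whether compound 1, compound 2 and compound 4 would show a stronger or weaker effect than one another at any other concentration also remains open.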